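The source may report more compounds than this note shows. Statements on the series, on what has been measured and on what is new or still open speak of the compounds shown alone.

Going by the values given here, compound 2 `C/C1=C\CC[C@@]2(C)O[C@@H]2[C@H]2OC(=O)[C@@H](CN3CCN(C)CC3)[C@@H]2C[C@H]1O` gives in a functional assay on A549 cells (Homo sapiens) for inhibition, read by colorimetric assay and MTT assay, with a stated time of 72 h (on this read-out higher numbers stand for weaker inhibition and lower numbers for stronger inhibition), a value of 30000 nM, the highest of the three numbers known so far. Compound 1 `C/C1=C\CC[C@@]2(C)O[C@@H]2[C@H]2OC(=O)[C@@H](CN3CCCCC3)[C@@H]2C[C@H]1O` gives in this assay 18000 nM, and compound 3 `COc1ccc(N2CCN(C[C@@H]3C(=O)O[C@H]4[C@H]3C[C@@H](O)/C(C)=C/CC[C@@]3(C)O[C@H]43)CC2)cc1` gives in this assay 26000 nM. The two steps connecting them, a 1.7-fold higher number from compound 1 to compound 2 (0.22 log units; within the scatter) and a 1.2-fold lower number from compound 2 to compound 3 (0.06 log units; within the scatter), both lie within the scatter, so the three compounds cannot be ordered. Compound 4 `C/C1=C\CC[C@@]2(C)O[C@@H]2[C@H]2OC(=O)[C@@H](CN3CCN(C)CC3)[C@@H]2C[C@@H]1O` differs from compound 2 only in the two compounds have the same atoms and bonds and differ only in configuration as drawn: 1 of 7 stereo elements differ; a stereocentre at a saturated ring carbon is drawn R in compound 2 and S in compound 4. Neither measured step bears on such a change; both swap groups on the amine rather than altering configuration, so the data give no footing for expecting a step in this assay beyond the scatter. Compound 4 is therefore estimated at 30000 nM, within 10000 nM to 90000 nM, a step of no change at the digits printed from compound 2 to compound 4 (within the scatter) that is expected to stay within the scatter.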

Compound 4, half-maximal inhibitory concentration: 25000 nM
Compound 4: the middle estimate sits 1.2-fold (0.08 log units) above what was measured, within the range that was stated.
By their numbers in this assay, from the lowest: compounds 1, 4, 3 and 2 (each within the scatter of the next).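

In this assay, the change of configuration gives a 1.2-fold lower number from compound 2 to compound 4 (0.08 log units; within the scatter), so redrawing this saturated ring carbon from R to S leaves the number within the scatter. The earlier steps shown here only swapped groups on the amine and so said nothing about configuration at this position. This comparison rests on a single stereo element: the fact that compounds 2 and 4 differ only in the configuration as drawn

The compounds shown leave open whether the same holds with piperidin-1-yl in place of 4-methylpiperazin-1-yl. They also leave open how a primary amine or a carboxylic acid on the saturated chain carbon would read in this assay.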